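A few compounds are considered here, and "the series" means these few. Any claim that something is new, unique, unknown or untested is made for them only; others in the source may bear on it.

Of the compounds shown here, three built on one shared core have been measured in an ADME assay for permeability, using PAMPA, with a stated time of 4 h; on this read-out higher numbers stand for higher permeability and lower numbers for lower permeability. Compound 1 `Cn1c(COc2cccc(C(=O)O)c2)nc2ccc(Oc3ccc(Cl)c(F)c3)nc21` gives 25.6 10^-6 cm/s in this assay. Compound 2 `Cn1c(COc2cccc(C(=O)O)c2)nc2cnc(Oc3ccc4c(c3)CCC4)cc21` gives 16.5 10^-6 cm/s. Compound 3 `Cn1c(COc2cccc(C(=O)O)c2)nc2ccc(Oc3ncccc3Cl)cc21` gives 8.1 10^-6 cm/s, the lowest of the three numbers: its gap to compound 2 and its wider gap to compound 1 both lie beyond the usual scatter of repeated measurements, so among these three compound 3 is the least permeable as measured here.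

Compound 4 `Cc1cc(Cl)cnc1Oc1ccc2nc(COc3cccc(C(=O)O)c3)n(C)c2c1` has not yet been measured. It differs from compound 3 in a single place:

5-chloro-3-methylpyridin-2-yl in place of 3-chloropyridin-2-yl on an oxygen on an aromatic ring

For the measured compounds named here, no pair of measured compounds shows this exact change, so nothing measured tells how large its effect is. The expectation therefore rests on compound 3 alone. A step in this assay that is small and upward, of a size that could still fall within the scatter, is expected, and the estimated step of a 1.4-fold higher number from compound 3 to compound 4 (0.13 log units; within the scatter) reflects that. On this basis compound 4 is expected to give about 11 10^-6 cm/s in this assay, with a plausible range from 5 10^-6 cm/s to 24 10^-6 cm/s.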

Compound 4, apparent permeability: 13.7 10^-6 cm/s
For compound 4 the middle estimate is 1.2-fold (0.10 log units) below the measured one; low and high end bracket the measured number.
By their numbers in this assay, from the lowest: compounds 3, 4, 2 and 1 (each within the scatter of the next, the first and the last beyond it).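

In this assay, the step for putting 5-chloro-3-methylpyridin-2-yl in place of 3-chloropyridin-2-yl on an oxygen on an aromatic ring is a 1.7-fold higher number from compound 3 to compound 4 (0.23 log units; within the scatter) and so compound 3 and compound 4 cannot be told apart on this read-out. This is the first pair shown that differs in one place, and it gives a first direct reading at this position: a group with one extra carbon and a different chlorine number in its name leaves the result within the usual scatter. No measured explanation for this outcome is available.

As far as these compounds go, what a 3-methylpyridin-2-yl or a 5-chloropyridin-2-yl group would give on the same oxygen remains open, so the methyl and the place of the chlorine cannot yet be judged apart from each other. Also open, from the compounds shown here alone, is how far this single reading carries to other groups at this position, such as an unsubstituted phenyl ring or a longer chain such as a butyl group on the oxygen.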